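Amide variation in the dienamide series: toward compound 4

A few compounds are considered here, and "the series" means these few. Any claim that something is new, unique, unknown or untested is made for them only; others in the source may bear on it.

In a functional assay on IMR-32 cells (Homo sapiens) for antiproliferative activity, read by sulforhodamine B assay, with a stated time of 48 h (a lower number here means a stronger inhibitor, a higher number a weaker inhibitor), compound 3 `CCN1CCN(C(=O)/C=C/C=C/[C@H](O)Cc2ccc(OC)c(OC)c2)CC1` gives 10800 nM. Its number is the second highest of the three measured, but the set is flat: compound 1 `CCNC(=O)/C=C/C=C/[C@H](O)Cc1ccc(OC)c(OC)c1` gives 9430 nM and compound 2 `COc1ccc(C[C@@H](O)/C=C/C=C/C(=O)N2CCCCC2)cc1OC` gives 11000 nM. The steps of a 1.2-fold higher number from compound 1 to compound 2 (0.07 log units; within the scatter), a 1.1-fold higher number from compound 1 to compound 3 (0.06 log units; within the scatter) and a 1.0-fold lower number from compound 2 to compound 3 (0.01 log units; within the scatter) all stay within the scatter, so swapping the amide substituent has so far not moved the read-out.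

The next change is benzylamino in place of 4-ethylpiperazin-1-yl on a carbonyl carbon, giving compound 4 `COc1ccc(C[C@@H](O)/C=C/C=C/C(=O)NCc2ccccc2)cc1OC`. The three amide swaps already seen bear directly on it and were all flat, so no step beyond the scatter is expected in this assay; the expected step is a 1.1-fold lower number from compound 3 to compound 4 (0.03 log units; within the scatter). Compound 4 is estimated at 10000 nM, within 4000 nM to 25000 nM.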

Compound 4, half-maximal inhibitory concentration: 16600 nM
Compound 4: the middle estimate sits 1.7-fold (0.22 log units) below what was measured; the measured number falls inside the stated range.
By their numbers in this assay, from the lowest: compounds 1, 3, 2 and 4 (each within the scatter of the next).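

Benzylamino on the carbonyl carbon brings in an aromatic ring of carbon only and an amide hydrogen, yet this assay still shows only steps within the scatter (a 1.5-fold higher number from compound 3 to compound 4 (0.19 log units; within the scatter)) (a 1.5-fold higher number from compound 2 to compound 4 (0.18 log units; within the scatter)) (a 1.8-fold higher number from compound 1 to compound 4 (0.25 log units; within the scatter)). The flat picture therefore extends from the ethylamino, piperidin-1-yl and 4-ethylpiperazin-1-yl amides to this aromatic substituent. No evidence on the cause is available. Still open, on these data alone, is whether a carboxylic acid in place of the amide, or a longer chain carrying the phenyl ring, would give a step beyond the scatter.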